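From dimethoxyphenyl to fluoro-methoxyphenyl in a cell assay

A few compounds are considered here, and "the series" means these few. Any claim that something is new, unique, unknown or untested is made for them only; others in the source may bear on it.

Values measured in a functional assay on MV4-11 cells (Homo sapiens) for antiproliferative activity, read by luminescence and CellTiter-Glo, with a stated time of 72 h (a higher number here means a weaker inhibitor, a lower number a stronger inhibitor), are these
- Compound 1 `Cc1noc(C)c1-c1ccc2c(Nc3ccc(F)cc3)nn(C3CCCCO3)c2c1` gives 9900 nM
- Compound 2 `Cc1noc(C)c1-c1ccc2c(Nc3ccc(Cl)cc3)nn(C3CCCCO3)c2c1` gives 7400 nM
- Compound 3 `CNc1cc(-c2ccc3cnn(Cc4cc(OC)cc(OC)c4)c3c2)cn(C)c1=O` gives 190 nM

Compound 3 at 190 nM has the lowest number of the three and stands apart from both others by more than the scatter. Compound 4 `CNc1cc(-c2ccc3cnn(Cc4ccc(OC)c(F)c4)c3c2)cn(C)c1=O` keeps the core of compound 3 and differs from it by one exchange, 3-fluoro-4-methoxyphenyl in place of 3,5-dimethoxyphenyl on a saturated chain carbon bound to an aromatic nitrogen with 3-fluoro-4-methoxyphenyl in place of 3,5-dimethoxyphenyl on a saturated chain carbon bound to an aromatic nitrogen.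

Among the measured compounds shown here, only one measured step exists here, a 1.3-fold lower number from compound 1 to compound 2 (0.13 log units; within the scatter) with chloro in place of fluoro on an aromatic carbon. That step lies on a different core and within the scatter, so it bears only loosely on this exchange. For the measured compounds named here, no measured step touches the group that changes, and the size of the step has to be judged with little support. The expected step is a 1.6-fold higher number from compound 3 to compound 4 (0.20 log units; within the scatter) and stays within the scatter. Its lean toward a higher number rests only on compound 3 having 190 nM as the lowest number seen so far. For compound 4 the estimated value is 300 nM and the expected range runs from 100 nM to 900 nM as its upper end.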

Compound 4, half-maximal inhibitory concentration: 4980 nM
Estimate against measurement, compound 4: 17-fold (1.22 log units) below; measured number outside the range, above it.
By their numbers in this assay, from the lowest: compound 3; then compounds 4, 2 and 1 (each within the scatter of the next).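

On the shared core of compound 3 and compound 4, the aromatic group on a saturated chain carbon bound to an aromatic nitrogen proves to weigh heavily in this assay: one exchange, 3-fluoro-4-methoxyphenyl in place of 3,5-dimethoxyphenyl, gives a large step beyond the scatter (a 26-fold higher number from compound 3 to compound 4 (1.42 log units; beyond the scatter)). Among the compounds shown here, the earlier compounds gave no view of this place, since their only step (a 1.3-fold lower number from compound 1 to compound 2 (0.13 log units; within the scatter)) lay on a different core, concerned a different group and stayed within the scatter. The exchange changes more than one feature of the ring at once, with one oxygen fewer and a fluorine entering, and nothing available here bears on what lies behind the size of this step.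

The compounds shown leave open which part of the exchange carries the step, the change in the methoxy groups or the arrival of the fluoro. They also leave open how this place would respond to a ring bearing an amine or a carboxylic acid, or to a longer chain between the aromatic nitrogen and the ring.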